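Cyclopentyl for hexyl on the amine of the triazolopyrimidine series

The source may hold more compounds than are shown below. What is called first, only, known or untested is meant among the compounds shown, and "the series" means these compounds.

Measured compounds:
- compound 1, `Clc1ccccc1Cn1nnc2c(NC3CCC3)nc(-c3ccccc3)nc21`: 24000000 nM
- compound 2, `FC(F)(F)c1ccccc1Cn1nnc2c(NC3CCCC3)nc(-c3ccccc3)nc21`: 600000 nM
- compound 3, `CCCCCCNc1nc(-c2ccccc2)nc2c1nnn2Cc1ccccc1Cl`: 31000000 nM

In an assay on isolated protein for binding affinity to adenosine receptor A1 (Bos taurus) (a lower number here means a stronger inhibitor, a higher number a weaker inhibitor), compound 3 gives the highest of the three numbers. Its nearest neighbour is compound 1, and the step of a 1.3-fold higher number from compound 1 to compound 3 (0.11 log units; within the scatter) shows that hexyl in place of cyclobutyl on the ring nitrogen left the number where it was. Compound 2, the furthest of the three, differs from compound 3 in two places at once, so its values are only read side by side with those of compound 3 and not as a single step.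

Compound 4, `Clc1ccccc1Cn1nnc2c(NC3CCCC3)nc(-c3ccccc3)nc21`, is not yet measured. It differs from compound 3 as follows: cyclopentyl in place of hexyl on a nitrogen on an aromatic ring. Of the measured steps only a 1.3-fold higher number from compound 1 to compound 3 (0.11 log units; within the scatter) touches the same nitrogen, and it lay within the scatter. Compound 2 carries the same cyclopentyl but also a different group on the benzyl ring, so its lower number cannot be credited to the cyclopentyl alone. A step of about the same size as the cyclobutyl-to-hexyl step is therefore expected, with some room for a lower number. For compound 4 the estimate in this assay is 10000000 nM, with a range from 1000000 nM to 40000000 nM, which means an expected step of a 3.1-fold lower number from compound 3 to compound 4 (0.49 log units; beyond the scatter).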

Compound 4, inhibition constant: 9000000 nM
Estimate against measurement, compound 4: 1.1-fold (0.05 log units) above; low and high end bracket the measured number.
By their numbers in this assay, from the lowest: compound 2; then compound 4; then compounds 1 and 3 (each within the scatter of the next).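

In this assay, the group on the amine nitrogen now shows a measurable effect: hexyl and cyclobutyl could not be separated (a 1.3-fold higher number from compound 1 to compound 3 (0.11 log units; within the scatter)), whereas cyclopentyl stands apart from both (a 3.4-fold lower number from compound 3 to compound 4 (0.54 log units; beyond the scatter); a 2.7-fold lower number from compound 1 to compound 4 (0.43 log units; beyond the scatter)), and compound 1 goes against any simple reading of ring against open chain, since its cyclobutyl ring sits with the hexyl chain of compound 3. Among the compounds shown here, with cyclopentyl held constant, the change on the aromatic carbon can be read alone for the first time (a 15-fold higher number from compound 2 to compound 4 (1.18 log units; beyond the scatter)), and it is the largest of the new steps, so most of the lower number of compound 2 goes with trifluoromethyl rather than with cyclopentyl. No available evidence accounts for either step.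

For the compounds shown here, whether trifluoromethyl gives a similar step alongside hexyl or cyclobutyl remains open, as the only pair that reads this change carries cyclopentyl. The compounds shown also leave open how cyclohexyl or a shorter chain such as butyl would fall on the amine, and how bromo or methoxy would compare with chloro and trifluoromethyl on the aromatic carbon.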